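Chromone ether series: methoxycarbonyl added to the benzamide

A few compounds are considered here, and "the series" means these few. Any claim that something is new, unique, unknown or untested is made for them only; others in the source may bear on it.

Of the compounds shown here, three have been measured in an assay on isolated protein for inhibition of Rho-associated protein kinase 1 (Homo sapiens), read by scintillation counting, radiometric assay and 33P incorporation, with a stated time of 40 min, in the presence of a further agent that is not named here; on this read-out higher numbers stand for weaker inhibition and lower numbers for stronger inhibition. Compound 1 `COc1ccc(OCC(=O)Nc2cccc(NC(=O)c3ccc(N(C)C)cc3)c2)cc1OC` reports only the assay limit, > 10000 nM. Compound 2 `Cc1coc2cc(OCC(=O)Nc3cccc(NC(=O)c4ccc(N(C)C)cc4)c3)ccc2c1=O` likewise reports only the assay limit, > 10000 nM. For the measured compounds named here, compound 3 `O=C(COc1ccc2c(=O)ccoc2c1)Nc1cccc(NC(=O)c2ccccc2)c1` is the one member with a numerical result, giving 120 nM in this assay, and so stands as the only anchor for any expectation.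

Compound 4 `COC(=O)c1ccc(C(=O)Nc2cccc(NC(=O)COc3ccc4c(=O)ccoc4c3)c2)cc1` has not yet been measured. It differs from compound 3 in one place: methoxycarbonyl in place of hydrogen on an aromatic carbon. The new group sits on an aromatic carbon of a six-membered aromatic ring of carbon only, para to a large group; cut one bond further out, the change reads phenyl to 4-(methoxycarbonyl)phenyl.

Going by the values given here, no step between measured compounds is recorded, so the size of the step cannot be read from the series. Compounds 1 and 2 carry a different group at the same position and a different aryl ether, and report only limits, which gives no usable direction. The step from compound 3 to compound 4 is expected to be small, within the usual scatter or a modest weakening, a 1.7-fold higher number from compound 3 to compound 4 (0.22 log units; within the scatter). Compound 4 is therefore estimated at 200 nM in this assay, with a range of 60 nM to 800 nM.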

Compound 4, half-maximal inhibitory concentration: 72 nM
Beside the measured number, compound 4's estimate is 2.8-fold (0.44 log units) above it; measured number inside the range.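

Methoxycarbonyl in place of hydrogen on an aromatic carbon, para to a large group, gives the series its first single-place comparison, and in this assay it reads as a 1.7-fold lower number from compound 3 to compound 4 (0.22 log units; within the scatter). The position therefore accepts methoxycarbonyl with the reading still inside the usual scatter, so this substituent neither clearly gains nor clearly loses inhibition relative to the unsubstituted phenyl. The earlier compounds shown here could not show this: compound 1 and compound 2 report only assay limits, and neither forms a single-place pair with compound 3.

Going by these compounds, whether the same position would also accept a carboxylic acid, a primary amine or a longer chain such as ethoxycarbonyl remains open, as one substituent on one ring position says nothing about the trend across other groups or about the other ring positions. Nothing measured in the series bears on why this step has the size it has, so the reading stands as an observation about this one pair.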